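This account rests on a few compounds, and the source may have more. Where it says the series, first, only, none or still open, it means among the compounds named here.

Compound 1 `Cc1c(OCCCCOc2ccc(F)c(C(=O)N(C)C)c2)ccc(C(=O)CC(C)(C)C)c1O`: in an assay for positive allosteric modulation of metabotropic glutamate receptor 2 (Rattus norvegicus) (a higher number here means that more compound is needed for the effect, a lower number that less compound is needed), compound 1 gives 3810 nM.
Compound 2 `Cc1c(O[C@H](C)COc2ccc(F)c(C(=O)O)c2)ccc(C(=O)CC(C)(C)C)c1O`: in this assay compound 2 gives 83 nM.
Compound 3 `Cc1c(OC[C@H](C)COc2ccc(F)c(C(=O)O)c2)ccc(C(=O)CC(C)(C)C)c1O`: in this assay compound 3 gives 294 nM.

Among these three numbers, compound 3 stands second highest. Its nearest neighbour is compound 2, whose number is lower by a margin beyond the usual scatter, while compound 1 sits far higher, also beyond the scatter. Compound 4 `Cc1c(OC[C@@H](C)COc2ccc(F)c(C(=O)O)c2)ccc(C(=O)CC(C)(C)C)c1O` has not yet been measured. It differs from compound 3 only in this way: the two compounds have the same atoms and bonds and differ only in configuration as drawn: 1 of 1 stereo elements differ; a stereocentre at a saturated chain carbon is drawn R in compound 3 and S in compound 4. For the measured compounds named here, no measured pair here differs solely in such a configuration, so the data give no guide to the size or direction of this step. The step from compound 3 to compound 4 in this assay is therefore expected to be a 1.2-fold higher number from compound 3 to compound 4 (0.08 log units; within the scatter), with a wide margin either way. Compound 4 is estimated at 350 nM, ranging from 90 nM to 1500 nM.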

Compound 4, half-maximal effective concentration: 112 nM
The estimate for compound 4 lay 3.1-fold (0.49 log units) above the measured number; measured number inside the range.
By their numbers in this assay, from the lowest: compounds 2 and 4 (each within the scatter of the next); then compound 3; then compound 1.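

For the compounds shown here, this is the first pair that isolates a single stereocentre, and it shows that the configuration at this saturated chain carbon matters: in this assay the change gives a 2.6-fold lower number from compound 3 to compound 4 (0.42 log units; beyond the scatter). The S form needs less compound than the R form, by a modest margin that lies beyond the usual scatter. The gap can be traced to this stereocentre alone, because of one fact: the fact that compounds 3 and 4 differ only in the configuration as drawn.

From the compounds shown here alone, what an ethyl or hydroxyl group at this stereocentre would do remains open. So does whether the S form would keep its edge with such a group.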